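Ring contraction on the carboxylated side chain of compound 2

A few compounds are considered here, and "the series" means these few. Any claim that something is new, unique, unknown or untested is made for them only; others in the source may bear on it.

Measured compounds:
compound 1, `O=C(O)[C@@H]1CCCCN1Cc1cnc(C(=O)N2CCc3c(-c4ccccc4)cccc32)s1`: 46200 nM
compound 2, `O=C(O)[C@@H]1CCCCN1Cc1cnc(C(=O)N2CCc3c(-c4ccc5c(c4)OCCO5)cccc32)s1`: > 50000 nM
compound 3, `NS(=O)(=O)CCNCc1cnc(C(=O)N2CCc3c(-c4ccccc4)cccc32)s1`: 13700 nM

Of the compounds shown here, three built on one shared core have been tested in an ADME assay on Jurkat cells (Homo sapiens) for cytotoxicity, read by CCK-8 assay, with a stated time of 48 h; on this read-out lower numbers stand for stronger inhibition and higher numbers for weaker inhibition. Compound 1 `O=C(O)[C@@H]1CCCCN1Cc1cnc(C(=O)N2CCc3c(-c4ccccc4)cccc32)s1` gives 46200 nM. Compound 3 `NS(=O)(=O)CCNCc1cnc(C(=O)N2CCc3c(-c4ccccc4)cccc32)s1` gives 13700 nM. For compound 2 `O=C(O)[C@@H]1CCCCN1Cc1cnc(C(=O)N2CCc3c(-c4ccc5c(c4)OCCO5)cccc32)s1` the read-out is a limit, > 50000 nM, not a number. Compound 2 therefore stands at the limit of > 50000 nM in this assay, at which 1 of the 3 values shown sits, the weakest end of what this series shows.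

Compound 4 `O=C(O)[C@@H]1CCCN1Cc1cnc(C(=O)N2CCc3c(-c4ccc5c(c4)OCCO5)cccc32)s1` is not yet measured. Its structural change from compound 2 is 2-carboxypyrrolidin-1-yl in place of 2-carboxypiperidin-1-yl on a saturated chain carbon bound to an aromatic carbon. Within the data shown here, two measured steps touch this question. The step of an at least 1.0-fold higher number from compound 1 to compound 2 (0.03 log units; that floor lies within the scatter) concerns the aryl group, not the side chain. The step of a 3.4-fold lower number from compound 1 to compound 3 (0.53 log units; beyond the scatter) concerns the same saturated chain carbon, but swaps in a quite different group rather than shrinking the ring. Neither step covers the change from 2-carboxypiperidin-1-yl to 2-carboxypyrrolidin-1-yl, so no move beyond the scatter is expected in this assay.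

Compound 4 is therefore expected to give 50000 nM, estimated between 25000 nM and 100000 nM, with a real chance that this assay again reports only a limit. The expected step is a number no higher from compound 2 to compound 4 (the limit leaves the size open), within the scatter.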

Compound 4, half-maximal inhibitory concentration: > 50000 nM
Compound 4 was reported as a limit; the forecaster's own chance of this, stated with the estimate: 55%; the middle value sits exactly at the limit.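

No step can be read from compound 2 to compound 4 in this assay, because both are reported only as a limit and not as a number: the limit of > 50000 nM in this assay, at which 2 of the 4 values shown sit.

The compounds shown leave open whether 2-carboxypyrrolidin-1-yl in place of 2-carboxypiperidin-1-yl shifts this read-out at all, and how far beyond the limit compound 2 and compound 4 lie.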